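A few compounds are considered here, and "the series" means these few. Any claim that something is new, unique, unknown or untested is made for them only; others in the source may bear on it.

Measured compounds: compound 1 `CC(=O)N1N=C(Nc2nc3ccc(C)cc3s2)CC1c1ccc(Cl)cc1` with 25.5 umol/kg; compound 2 `CC(=O)N1N=C(Nc2nc3ccc([N+](=O)[O-])cc3s2)CC1c1ccc(Cl)cc1` with 132 umol/kg; compound 3 `Cc1ccc2nc(NC(=O)/C=C/c3ccc(Cl)cc3)sc2c1` with 152 umol/kg.

In a functional assay on the whole organism (Hindlimb, strain albino) with Mus musculus as the target, in the maximal electroshock model, with a stated time of 0.5 h (on this read-out higher numbers stand for an effect only at larger amounts of compound and lower numbers for an effect already at smaller amounts), compound 1 gives 25.5 umol/kg. The change nitro in place of methyl on an aromatic carbon gives a 5.2-fold higher number from compound 1 to compound 2 (0.71 log units; beyond the scatter). Compound 3 shares this read-out, and how its core differs from that of compound 1 is not broken down here; its value and that of compound 2 lie within the scatter of each other. Compound 4 `O=C(/C=C/c1ccc(Cl)cc1)Nc1nc2ccc([N+](=O)[O-])cc2s1` is unmeasured and carries the same change on the core of compound 3, (nitro in place of methyl on an aromatic carbon), at the same place as before. The expectation for compound 4 is a 3.9-fold higher number from compound 3 to compound 4 (0.60 log units; beyond the scatter), set beside the earlier step because a 5.2-fold higher number from compound 1 to compound 2 (0.71 log units; beyond the scatter) is the only measured case of this change. For compound 4 the estimated value is therefore 600 umol/kg, expected between 200 umol/kg and 1600 umol/kg.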

Compound 4, dose for half-maximal effect: 259 umol/kg
For compound 4 the middle estimate is 2.3-fold (0.36 log units) above the measured one; measured number inside the range.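

In this assay, among the compounds shown here, nitro in place of methyl gives a 1.7-fold higher number from compound 3 to compound 4 (0.23 log units; within the scatter), so on the core of compound 3 the change produces no step that can be told from the scatter. The size of the step did not carry over from one core to the other, as the two steps differ: the same change on two cores in this assay, a 5.2-fold higher number (0.71 log units; beyond the scatter) from compound 1 to compound 2 and a 1.7-fold higher number (0.23 log units; within the scatter) from compound 3 to compound 4, 3.0-fold (0.48 log units) apart, beyond the scatter of two such steps. This shows that the outcome of the change depended on the core in these two pairs, but it does not show which difference between the cores matters or how the change would behave on a further core.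

The compounds shown leave open how other groups at this place, such as an amine or a methoxy group, would compare with methyl and nitro. They also leave open what either core would give with only hydrogen there.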